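Phenoxy for Chloro in a Series Stuck at the Limit

A few compounds are considered here, and "the series" means these few. Any claim that something is new, unique, unknown or untested is made for them only; others in the source may bear on it.

Compound 1 (`COc1ccc(/C=C/C(=O)/C=C/c2cc3ccccc3nc2Cl)cc1`), compound 2 (`COc1ccc(/C=C/C(=O)/C=C/c2cc3ccccc3nc2Cl)c(OC)c1`) and compound 3 (`COc1cc(OC)c(/C=C/C(=O)/C=C/c2cc3ccccc3nc2Cl)c(OC)c1`) share one core and differ only in their methoxy groups. In a functional assay on NCI-H460 cells (Homo sapiens) for cytotoxicity, read by MTT assay, with a stated time of 48 h (a higher number here means a weaker inhibitor, a lower number a stronger inhibitor), compound 1 gives > 10000 nM as a limit, not a number. Compound 2 gives > 10000 nM as a limit too. Compound 3 gives > 10000 nM as a limit as well, so it stands with the other two. The whole set rests on the limit of > 10000 nM in this assay, at which 3 of the 3 values shown sit, and offers no true number.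

Compound 4 (`COc1cc(OC)c(/C=C/C(=O)/C=C/c2cc3ccccc3nc2Oc2ccccc2)c(OC)c1`) keeps everything in compound 3 except one group (phenoxy in place of chloro on an aromatic carbon), with phenoxy in place of chloro, next to the ring nitrogen. The two measured steps (a step that the two limits leave unreadable from compound 1 to compound 2 and a step that the two limits leave unreadable from compound 2 to compound 3) each put methoxy in place of hydrogen, a different change at a different place, and neither has a size to carry over. Among the compounds with values here, no compound here shows what replacing chloro does. A readable value in this assay could only lie on the stronger side of that limit, so a modest gain is the expected direction, though compound 4 may well stay at the limit. The expected size, loosely estimated, is an at least 2.0-fold lower number from compound 3 to compound 4 (0.30 log units; that floor lies within the scatter) in that direction. The estimated value for compound 4 is 5000 nM within an expected range from 800 nM to 20000 nM in this deliberately wide estimate.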

Compound 4, half-maximal inhibitory concentration: > 10000 nM
Compound 4 ended at the assay's limit (the forecaster's own chance of this, stated with the estimate: 45%); middle value at least 2.0-fold (0.30 log units) away from the limit.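

In this assay compound 4 gives > 10000 nM, which is a limit and not a number. No size can be read for the change from compound 3 to compound 4, because both rest on the same limit: the limit of > 10000 nM in this assay, at which 4 of the 4 values shown sit.

The compounds shown leave open what phenoxy in place of chloro does to potency, and what would bring this series to a readable value.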